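The source may hold more compounds than are shown below. What is called first, only, known or untested is meant among the compounds shown, and "the series" means these compounds.

Measured so far in an ADME assay for permeability, using PAMPA, at pH 7.4; a lower number here means that the compound crosses the layer more slowly, a higher number that the compound crosses the layer faster:

- compound 1, `O=C(Nc1nc(-c2ccc(Cl)cc2)cs1)c1cc([N+](=O)[O-])ccc1Cl`, 3 10^-6 cm/s
- compound 2, `O=C(Nc1ccc(O)c(-c2nc3ccccc3s2)c1)c1cc([N+](=O)[O-])ccc1Cl`, no single number reported
- compound 3, `O=C(Nc1ccc(F)c(-c2nc3ccccc3s2)c1)c1cc([N+](=O)[O-])ccc1Cl`, 17 10^-6 cm/s

Compound 3 holds the higher of the two numbers reported. Its nearest neighbour in this assay is compound 1, whose value lies well under it, a gap beyond the usual scatter of repeated runs. For compound 2 this assay reports no number, only "below limit of detection" (no number reported), so it cannot be placed on the same scale.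

The next compound, compound 4, `COc1ccc(NC(=O)c2cc([N+](=O)[O-])ccc2Cl)cc1-c1nc2ccccc2s1`, keeps the shared core of compound 3 and changes one group:

methoxy in place of fluoro on an aromatic carbon

Going by the values given here, no pair of measured compounds differs in just this way, so there is no measured step to lean on. The closest comparison is between compound 3 and compound 1, but those two differ in several places at once and only show that the series spans a wide span in this assay. The change from fluoro to methoxy adds one hydrogen-bond acceptor, and on the record of compounds 1 and 3 alone no direction can be read off with confidence. The expected step of a 1.4-fold lower number from compound 3 to compound 4 (0.15 log units; within the scatter) is therefore small, at most a modest drop, within or just beyond the scatter. Compound 4 is estimated at 12 10^-6 cm/s, with a range of 5 10^-6 cm/s to 25 10^-6 cm/s.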

Compound 4, apparent permeability: "below limit of detection" (no number reported)
For compound 4 the study gives words and no number, so the estimate cannot be set against anything.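

In this assay no step can be read from compound 3 to compound 4; compound 4 is reported in words, without a number. No measurement shown here bears on this result. The compounds shown leave open how large the change from fluoro to methoxy is on this read-out.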